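The source may hold more compounds than are shown below. What is called first, only, known or untested is meant among the compounds shown, and "the series" means these compounds.

The compounds measured so far:
compound 1, `Cc1ccc(-c2cc(/N=C3/NC(=O)CS3)cs2)cc1`: in a functional assay on MCF7 cells (Homo sapiens) for cytotoxicity, read by MTT assay, with a stated time of 72 h (on this read-out higher numbers stand for weaker inhibition and lower numbers for stronger inhibition), compound 1 gives > 50000 nM, which is a limit of the assay and not a number.
compound 2, `COc1ccc(/C=C2\S/C(=N\c3csc(-c4ccc(Cl)cc4)c3)NC2=O)cc1`: in this assay compound 2 gives 1000 nM.
compound 3, `CN(C)c1ccc(/C=C2\S/C(=N\c3csc(-c4ccc(Cl)cc4)c3)NC2=O)cc1`: in this assay compound 3 gives 400 nM.

Compound 2 thus stands at the highest of the two numbers shown; its nearest neighbour is compound 3, reached by a 2.5-fold lower number from compound 2 to compound 3 (0.40 log units; beyond the scatter). Compound 1 sits only at the limit of > 50000 nM in this assay, at which 1 of the 3 values shown sits, so it adds no number to compare with.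

Compound 4, `CCCCCC/C=C1\S/C(=N\c2csc(-c3ccc(Cl)cc3)c2)NC1=O`, differs from compound 2 by hexyl in place of 4-methoxyphenyl on a double-bonded chain carbon bound to a double-bonded ring carbon. For the measured compounds named here, only one measured step touches this part of the shared core, the step from compound 2 to compound 3, and it exchanges one group on an aromatic carbon for another while the aromatic ring itself stays. Going by the values given here, no measured step removes that ring or puts an open chain in its place, so the measured data bear on compound 4 only loosely. The step from compound 2 to compound 4 is expected to be a 3.0-fold higher number from compound 2 to compound 4 (0.48 log units; beyond the scatter), a rise in number, with wide uncertainty. Compound 4 is therefore estimated to give 3000 nM in this assay, between 700 nM and 15000 nM.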

Compound 4, half-maximal inhibitory concentration: > 50000 nM
Compound 4: no number, only a limit; the forecaster's own chance of this, stated with the estimate: 15%; middle value at least 16-fold (1.22 log units) from the limit.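

In this assay, hexyl in place of 4-methoxyphenyl on the double-bonded chain carbon gives an at least 50-fold higher number from compound 2 to compound 4 (1.69 log units; beyond the scatter), and hexyl in place of 4-(dimethylamino)phenyl gives an at least 120-fold higher number from compound 3 to compound 4 (2.09 log units; beyond the scatter), whereas the earlier exchange on the aromatic ring, with the ring kept, gave only a 2.5-fold lower number from compound 2 to compound 3 (0.40 log units; beyond the scatter). Losing the aromatic ring at this position therefore matters far more than exchanging a group on it, and compound 4 gives > 50000 nM, a limit of the assay and not a number, so the full size of both new steps stays unknown: the limit of > 50000 nM in this assay, at which 2 of the 4 values shown sit. Among compound 2, compound 3 and compound 4, the two with an aromatic ring at this position give numbers and the one with an open chain does not, with no compound here going against that pattern.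

As far as these compounds go, it remains open whether the loss of the aromatic ring or the hexyl chain itself accounts for the change, a question that a shorter chain such as ethyl or a saturated ring such as cyclohexyl could address. Also open, from the compounds shown here alone, is how a pyridine ring at this position, or a carboxylic acid on the aromatic ring, would compare with compound 3.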